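This account rests on a few compounds, and the source may have more. Where it says the series, first, only, none or still open, it means among the compounds named here.

Working notes on the series. The shared core, as in compound 1 `O=c1cc(CNCc2ccccc2)oc2ccc(O)c(O)c12`, carries a benzylamine-type side chain whose aryl group is varied. In an ADME assay on Huh-7 cells (Homo sapiens) for cytotoxicity (on this read-out lower numbers stand for higher toxicity in this test and higher numbers for lower toxicity in this test), compound 1 reaches only the limit of the test, > 100000 nM. Compound 2 `Cc1ccccc1CNCc1cc(=O)c2c(O)c(O)ccc2o1` differs by a methyl in place of hydrogen on an aromatic carbon; in this assay compound 2 gives 52200 nM, which is an at least 1.9-fold lower number from compound 1 to compound 2 (0.28 log units; that floor lies within the scatter). Compound 3 `O=c1cc(CNCc2cccc(Br)c2)oc2ccc(O)c(O)c12` carries a bromo in place of hydrogen on an aromatic carbon. In this assay compound 3 again sits at a limit, > 100000 nM. The step is a step that the two limits leave unreadable from compound 1 to compound 3, while an at least 1.9-fold higher number from compound 2 to compound 3 (0.28 log units; that floor lies within the scatter). Compound 3 thus stands only as a limit, and one further value shown is likewise a limit, namely (the limit of > 100000 nM in this assay, at which 2 of the 3 values shown sit).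

Compound 4 `O=c1cc(CNCc2ccc(F)cc2)oc2ccc(O)c(O)c12` brings (4-fluorophenyl in place of 3-bromophenyl on a saturated chain carbon bound to an amine nitrogen). Among the compounds with values here, the steps that bear on this change are those among compounds 1, 2 and 3, and none of them is readable as a clear movement beyond the scatter. The expected change from compound 3 is therefore none beyond the scatter, a number no higher from compound 3 to compound 4 (the limit leaves the size open). For compound 4 in this assay the estimate is 100000 nM, with a range from 50000 nM to 200000 nM, and most likely again only a limit.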

Compound 4, half-maximal cytotoxic concentration: > 100000 nM
Compound 4: only a limit was reported (the forecaster's own chance of this, stated with the estimate: 65%); the middle value lies on the limit itself.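

Compound 4 also stands as a limit and not a number, so the 4-fluorophenyl group joins the unsubstituted and 3-bromophenyl groups at the same limit in this assay: the limit of > 100000 nM in this assay, at which 3 of the 4 values shown sit.

The steps to compound 4 from compound 1 and from compound 3 cannot be read, as both ends of each are limits. Within the data shown here, the one new step that can be read is an at least 1.9-fold higher number from compound 2 to compound 4 (0.28 log units; that floor lies within the scatter); the 4-fluorophenyl result therefore adds no separation beyond the scatter.

From the compounds shown here alone, how far the compounds at the limit differ from one another stays open. Also open, going by these compounds, is whether a carboxylic acid, a dimethylamino group or a longer chain on the aryl ring would give a number within the range of the test.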